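This account rests on a few compounds, and the source may have more. Where it says the series, first, only, none or still open, it means among the compounds named here.

Within the data shown here, in a functional assay on A549 cells (Homo sapiens) for inhibition, read by CCK-8 assay, with a stated time of 72 h, tested at 10 uM (a lower number here means less inhibition of growth, a higher number more inhibition of growth at the concentration tested), compound 1 `COc1ccc(NC(=O)C2(C(=O)Nc3ccc(Nc4ncc5cc(C(=O)N(C)C)n(C6CCCC6)c5n4)cc3)CC2)cc1` gives 78.5%, the lower of the two numbers available so far, while compound 2 `CN(C)C(=O)c1cc2cnc(Nc3ccc(NC(=O)C4(C(=O)Nc5cccc(Cl)c5)CC4)cc3)nc2n1C1CCCC1` gives 90.7%. Compound 3 `CN(C)C(=O)c1cc2cnc(Nc3ccc(NC(=O)C4(C(=O)Nc5cccc(C#N)c5)CC4)cc3)nc2n1C1CCCC1` has not yet been measured. Its structure departs from that of compound 1 in one place: 3-cyanophenyl in place of 4-methoxyphenyl on an amide-type nitrogen. In short, 3-cyanophenyl takes the place of 4-methoxyphenyl on an amide-type nitrogen. Among the measured compounds shown here, one measured step bears on this change, the swap of the same 4-methoxyphenyl for 3-chlorophenyl, which gave a number 12.2 percentage points higher from compound 1 to compound 2 (beyond the scatter), a modest rise beyond the scatter. For the measured compounds named here, a nitrile is not a chlorine, and no measurement yet compares the two, so a rise in the same direction, of similar or slightly smaller size, is expected. The estimate amounts to a number 8.5 percentage points higher from compound 1 to compound 3 (within the scatter). For compound 3 the expected value is 87%, with an estimated range of 76% to 95%.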

Compound 3, percent growth inhibition at one concentration: 73.6%
The estimate for compound 3 lay 13.4 percentage points above the measured number; the whole stated range lies above it.
By their numbers in this assay, from the lowest: compounds 3 and 1 (each within the scatter of the next); then compound 2.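

In this assay, replacing 4-methoxyphenyl on the amide-type nitrogen does not by itself bring a gain: the 3-cyanophenyl swap gives a number 4.9 percentage points lower from compound 1 to compound 3 (within the scatter) and so cannot be told apart from the starting group. Among these compounds, the single exchange on the aromatic carbon, cyano in place of chloro, gives a number 17.1 percentage points lower from compound 2 to compound 3 (beyond the scatter) and shows that the higher number of compound 2 depends on the chloro and does not extend to this other substituent. Nothing available here measures a property of these groups that could explain the gap.

As far as these compounds go, whether a fluoro, a methyl or a carboxylic acid in place of the chloro would track compound 2 or compound 3 remains open. From the compounds shown here alone, each number also comes from a single concentration, so how these compounds compare across a range of concentrations is unknown.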